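A Pyridine Swap Tested on a Second Core

The source may hold more compounds than are shown below. What is called first, only, known or untested is meant among the compounds shown, and "the series" means these compounds.

Compound 1 `O=C([C@H]1CCN1S(=O)(=O)c1c(F)c(F)c(F)c(F)c1F)N(Cc1ccc(C2CCCCC2)cc1)c1ccc2c(=O)[nH]ccc2c1` and compound 3 `O=C([C@H]1CCN1S(=O)(=O)c1c(F)c(F)c(F)c(F)c1F)N(Cc1ccc(C2CCCCC2)cc1)c1cc2[nH]ncc2cc1F` share a core and differ in the group on the amide-type nitrogen, a difference counted as a group of 10 heavy atoms (7 carbon, 2 nitrogen, 1 fluorine; one five-membered aromatic ring with 2 hetero atoms, one six-membered aromatic ring of carbon only) in place of a group of 11 heavy atoms (9 carbon, 1 nitrogen, 1 oxygen; one six-membered aromatic ring of carbon only, one six-membered aromatic ring with 1 hetero atom), on an amide-type nitrogen. In a functional assay on MCF7 cells (Homo sapiens) for antiproliferative activity, with a stated time of 72 h (a higher number here means that more compound is needed for the effect, a lower number that less compound is needed), compound 1 gives 6200 nM, and compound 3 gives 9400 nM, the step between them being a 1.5-fold higher number from compound 1 to compound 3 (0.18 log units; within the scatter). Compound 2 `O=C([C@H]1CCN1S(=O)(=O)c1c(F)c(F)c(F)c(F)c1F)N(Cc1ccc(C2CCCCC2)cn1)c1ccc2c(=O)[nH]ccc2c1` carries the change (5-cyclohexylpyridin-2-yl in place of 4-cyclohexylphenyl on a saturated chain carbon bound to an amide-type nitrogen); in this assay compound 2 gives 2200 nM, and the resulting step is a 2.8-fold lower number from compound 1 to compound 2 (0.45 log units; beyond the scatter). Compound 4 `O=C([C@H]1CCN1S(=O)(=O)c1c(F)c(F)c(F)c(F)c1F)N(Cc1ccc(C2CCCCC2)cn1)c1cc2[nH]ncc2cc1F` applies the same change to the core of compound 3, namely (5-cyclohexylpyridin-2-yl in place of 4-cyclohexylphenyl on a saturated chain carbon bound to an amide-type nitrogen), at a place described in identical words to that in compound 2. Because the step of a 2.8-fold lower number from compound 1 to compound 2 (0.45 log units; beyond the scatter) lowered the number on the first core, a step of similar size is expected from compound 3 to compound 4 in this assay, estimated as a 2.7-fold lower number from compound 3 to compound 4 (0.43 log units; beyond the scatter), although this rests on a single measured pair and the second core has not been tested with this change. Compound 4 is therefore estimated at 3500 nM in this assay, with an expected range from 1500 nM to 8000 nM.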

Compound 4, half-maximal effective concentration: 4800 nM
Beside the measured number, compound 4's estimate is 1.4-fold (0.14 log units) below it; low and high end bracket the measured number.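

In this assay the change on the core of compound 3 gives a 2.0-fold lower number from compound 3 to compound 4 (0.29 log units; within the scatter), and it does not differ from the step on the core of compound 1: the same change on two cores in this assay, a 2.8-fold lower number (0.45 log units; beyond the scatter) from compound 1 to compound 2 and a 2.0-fold lower number (0.29 log units; within the scatter) from compound 3 to compound 4, 1.4-fold (0.16 log units) apart, within the scatter of two such steps. Exchanging the group on the amide-type nitrogen with 5-cyclohexylpyridin-2-yl in place gives a 2.2-fold higher number from compound 2 to compound 4 (0.34 log units; beyond the scatter), and this too agrees with its counterpart measured with 4-cyclohexylphenyl: the same change on two cores in this assay, a 1.5-fold higher number (0.18 log units; within the scatter) from compound 1 to compound 3 and a 2.2-fold higher number (0.34 log units; beyond the scatter) from compound 2 to compound 4, 1.4-fold (0.16 log units) apart, within the scatter of two such steps. The two cores are thus compatible with a change that carries over, but the step on the second core lies within the scatter on its own, so it does not by itself establish a lower number there, and two pairs in one cell assay make no general rule for this series.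

From the compounds shown here alone, it remains open whether the change would carry over to a third core, or with a morpholine or a tert-butyl group in place of the cyclohexyl ring. Whether the same holds in cell lines other than this one also stays unanswered.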